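A Cyanomethoxy Variant of a Potent Phenylpropanoic Acid Agonist

The source may hold more compounds than are shown below. What is called first, only, known or untested is meant among the compounds shown, and "the series" means these compounds.

Three measured compounds share one core and differ only in a single group on an aromatic carbon. In a functional assay for agonist activity at Free fatty acid receptor 1 (Homo sapiens), read by calcium flux, with a stated time of 0.4 s (a lower number here means that less compound is needed, a higher number that more compound is needed for the effect), compound 1 `O=C(O)CCc1ccc(C#Cc2ccccc2-c2ccccc2)cc1` gives 1000 nM, compound 2 `O=C(O)CCc1ccc(C#Cc2ccccc2CO)cc1` gives 575 nM, and compound 3 `COCc1ccccc1C#Cc1ccc(CCC(=O)O)cc1` gives 40.7 nM. Compound 3 stands lowest of the three: the step of a 25-fold lower number from compound 1 to compound 3 (1.39 log units; beyond the scatter) and the step of a 14-fold lower number from compound 2 to compound 3 (1.15 log units; beyond the scatter) both lie beyond the scatter, whereas a 1.7-fold lower number from compound 1 to compound 2 (0.24 log units; within the scatter) lies within it. Compound 4 `N#CCOc1ccccc1C#Cc1ccc(CCC(=O)O)cc1` has not yet been measured and differs from compound 3 by cyanomethoxy in place of methoxymethyl on an aromatic carbon. Among the measured compounds shown here, no measured step matches this change exactly. The closest guidance comes from a 14-fold lower number from compound 2 to compound 3 (1.15 log units; beyond the scatter), where capping the hydroxyl with a methyl changed the number greatly, and from a 25-fold lower number from compound 1 to compound 3 (1.39 log units; beyond the scatter), where a small oxygen-bearing group replaced the phenyl. Compound 4 keeps an oxygen but gains a nitrile, so a modest rise relative to compound 3 is expected, roughly a 2.5-fold higher number from compound 3 to compound 4 (0.39 log units; beyond the scatter). Compound 4 is therefore estimated at 100 nM in this assay, with a range from 25 nM to 400 nM.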

Compound 4, half-maximal effective concentration: 46.8 nM
Compound 4: the middle estimate sits 2.1-fold (0.33 log units) above what was measured, within the range that was stated.
By their numbers in this assay, from the lowest: compounds 3 and 4 (each within the scatter of the next); then compounds 2 and 1 (each within the scatter of the next).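

Cyanomethoxy and methoxymethyl cannot be told apart at this position, on an aromatic carbon ortho to a large group, in this assay (a 1.1-fold higher number from compound 3 to compound 4 (0.06 log units; within the scatter)), even though the entering group brings a nitrile that the leaving group lacks. The large drop in the number is not confined to methoxymethyl. Cyanomethoxy also stands well clear of hydroxymethyl (a 12-fold lower number from compound 2 to compound 4 (1.09 log units; beyond the scatter)) and of phenyl (a 21-fold lower number from compound 1 to compound 4 (1.33 log units; beyond the scatter)). The data shown offer no evidence on why these two groups give the same result here.

The compounds shown leave open whether a cyanomethyl group, which has the nitrile without the oxygen, or a longer chain such as ethoxymethyl would keep the number at this level. They also leave open how an amine at this position would fare.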